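Second Chloro Group on the Urea Aryl Ring

The compounds below may be only part of what the source reports. "The series", "measured", "known", "first", "only" and "open" are said of these compounds alone.

Compound 2 `Cc1cc(NC(=O)Nc2cccc(Cl)c2)c2ccccc2n1` stands second highest of the three compounds measured in a physicochemical assay for solubility, at pH 7.4 (on this read-out lower numbers stand for lower solubility and higher numbers for higher solubility), giving 800 nM. Compound 1 `Cc1cc(NC(=O)Nc2ccc(N)cc2)c2ccccc2n1` gives 18500 nM in this assay, and compound 3 `Cc1cc(NC(=O)Nc2ccc(O)cc2)c2ccccc2n1` gives 100 nM. Compound 4 `Cc1cc(NC(=O)Nc2cc(Cl)cc(Cl)c2)c2ccccc2n1` differs from compound 2 by chloro in place of hydrogen on an aromatic carbon, placed meta to a chloro group. The step that bears most directly on this is a 23-fold lower number from compound 1 to compound 2 (1.36 log units; beyond the scatter), where a chloro-bearing ring replaced an amino-bearing one; the step of an 8.0-fold lower number from compound 2 to compound 3 (0.90 log units; beyond the scatter) also moves downward. Within the data shown here, no measured pair adds a second chloro to the same ring. A modest downward step in this assay is therefore expected for compound 4, roughly a 3.2-fold lower number from compound 2 to compound 4 (0.51 log units; beyond the scatter). The estimate for compound 4 is 250 nM, with a range from 80 nM to 800 nM.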

Compound 4, solubility: 800 nM
Beside the measured number, compound 4's estimate is 3.2-fold (0.51 log units) below it, and the stated range covers the measured number.
By their numbers in this assay, from the lowest: compound 3; then compounds 2 and 4 (each within the scatter of the next); then compound 1.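

In this assay, chloro in place of hydrogen on an aromatic carbon, meta to a chloro group, gives no change at the digits printed from compound 2 to compound 4 (within the scatter). Each earlier step exchanged one group or ring for another and lay beyond the scatter, whereas this one adds a group to the ring of compound 2 and stays within it. This position therefore accepts a second chloro without a readable change in this read-out. Still open, on these data alone, is whether an amine or a carboxylic acid at this same position would leave the number equally unmoved. No measured evidence here accounts for this result.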